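One Group Exchanged: From Compound 2 to Compound 4

The compounds below may be only part of what the source reports. "The series", "measured", "known", "first", "only" and "open" are said of these compounds alone.

In an ADME assay on microsomes from liver (Rattus norvegicus) for metabolic stability (on this read-out lower numbers stand for a shorter-lived compound and higher numbers for a longer-lived compound), compound 2 (`COc1cc(OCc2cccc(-c3cnc(OC)cn3)c2)c2cc(-c3cn4nc(OC)sc4n3)oc2c1`) gives 1.62 h. Compound 3 (`COc1cc(OCc2csc(-c3ccc(C(C)(C)O)cc3)n2)c2cc(-c3cn4nc(OC)sc4n3)oc2c1`) gives 1.15 h, within the scatter of compound 2. Compound 1 (`COc1cc(OCc2cccc(-c3ccc(OC)nc3)c2)c2cc(-c3cn4nc(OC)sc4n3)oc2c1`) gives 0.633 h, which stands clearly lower than compound 2.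

Compound 4 (`COc1ccc(-c2cccc(COc3cc(OC)cc4oc(-c5cn6nc(OC)sc6n5)cc34)c2)nc1`) has not yet been measured. Its difference from compound 2 is 5-methoxypyridin-2-yl in place of 5-methoxypyrazin-2-yl on an aromatic carbon, on an aromatic carbon of a six-membered aromatic ring of carbon only, meta to a large group.

Going by the values given here, only one measured step bears on this change: a 2.6-fold higher number from compound 1 to compound 2 (0.41 log units; beyond the scatter), a modest step in which 5-methoxypyrazin-2-yl took the place of 6-methoxypyridin-3-yl. Among the compounds with values here, the group entering compound 4 is not the one carried by compound 1, and a single pair sets no rule, so that step serves only as a loose guide. A move to a lower number is expected, smaller than that step and possibly within the scatter. The estimated step is a 1.6-fold lower number from compound 2 to compound 4 (0.21 log units; within the scatter). For compound 4 the expected value is 1 h, with an estimated range from 0.5 h to 1.9 h.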

Compound 4, half-life: 0.317 h
The estimate for compound 4 lay 3.2-fold (0.50 log units) above the measured number, and the stated range ends above it.
By their numbers in this assay, from the lowest: compounds 4, 1, 3 and 2 (each within the scatter of the next, the first and the last beyond it).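

In this assay, the exchange of 5-methoxypyrazin-2-yl for 5-methoxypyridin-2-yl on this aromatic carbon gave a 5.1-fold lower number from compound 2 to compound 4 (0.71 log units; beyond the scatter), which shows that the half-life at this position is sensitive to the choice between these two groups. The two methoxypyridinyl groups stay close to each other, with a 2.0-fold lower number from compound 1 to compound 4 (0.30 log units; within the scatter), so compound 2 now stands clearly apart from both compound 1 and compound 4 among the compounds that differ only at this place. Nothing available here accounts for this gap in half-life.

On these data alone, it remains open whether the higher number of compound 2 is specific to the methoxy-substituted pyrazine or would persist with an amine or an ethoxy group in place of the methoxy. Whether a pyrimidine ring at this position would follow compound 2 or the two methoxypyridinyl compounds also remains unanswered.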